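Dropping a Ring Methyl From a Thiophene Inhibitor

The source may hold more compounds than are shown below. What is called first, only, known or untested is meant among the compounds shown, and "the series" means these compounds.

Of the compounds shown here, three have been measured in an assay (Equus caballus) for inhibition of Thromboxane-A synthase (Homo sapiens), using microsomes; on this read-out higher numbers stand for weaker inhibition and lower numbers for stronger inhibition. Compound 1 `C=C(C)C(CCC/C=C(\c1ccccc1)c1cccnc1)C(=O)O` gives 28 nM. Compound 3 `CC(C)(O)C(CCC/C=C(\c1ccccc1)c1cccnc1)C(=O)O` gives 42 nM. Compound 2 `Cc1ccsc1/C(=C/CCCCC(=O)O)c1cccnc1` gives 29 nM, which lies within the scatter of both compound 1 at 28 nM and compound 3 at 42 nM, so none of the three can be set apart from the others.

Compound 4 `O=C(O)CCCC/C=C(\c1cccnc1)c1cccs1` has not yet been measured. It differs from compound 2 in one place: hydrogen in place of methyl on an aromatic carbon. Among the compounds with values here, the only measured step, a 1.5-fold higher number from compound 1 to compound 3 (0.18 log units; within the scatter), concerns a change on the chain and not on the five-membered aromatic ring, so it tells nothing direct about removing a ring methyl. Nothing in the data points to a shift beyond the scatter in either direction. Compound 4 is therefore expected to give a number close to that of compound 2, an estimated step of a 1.2-fold higher number from compound 2 to compound 4 (0.08 log units; within the scatter), with the estimate for compound 4 in this assay being 35 nM and a range from 12 nM to 100 nM.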

Compound 4, half-maximal inhibitory concentration: 20 nM
For compound 4 the middle estimate is 1.8-fold (0.24 log units) above the measured one; the measured number falls inside the stated range.
By their numbers in this assay, from the lowest: compounds 4, 1, 2 and 3 (each within the scatter of the next, the first and the last beyond it).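

In this assay the change from 3-methylthiophen-2-yl to thiophen-2-yl gives a 1.5-fold lower number from compound 2 to compound 4 (0.16 log units; within the scatter) and so stays within the scatter. Within the data shown here, this is the first step on the five-membered aromatic ring, as the earlier step of a 1.5-fold higher number from compound 1 to compound 3 (0.18 log units; within the scatter) lies on the chain and says nothing about this aromatic carbon, two ring bonds from the ring sulfur. Here the methyl can go, leaving one carbon fewer, without a shift that can be told apart from repeated measurement, and nothing available accounts for this result.

Going by these compounds, whether an ethyl group, a methoxy group or an amine on this same aromatic carbon would also stay within the scatter remains open. Also open, on these data alone, is whether removing the methyl would give a similar result with a shorter chain carrying the carboxylic acid.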